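Ring closure at the amide terminus of compound 1

The compounds below may be only part of what the source reports. "The series", "measured", "known", "first", "only" and "open" are said of these compounds alone.

Measured compounds:
compound 1 `CC(C)(C)c1ccc(C(=O)N2CCC3(CC2)C(=O)N(CC(=O)NCCO)CN3c2ccccc2)cc1` 1000 nM
compound 2 `CC(C)(C)OC(=O)NCCCCNC(=O)CN1CN(c2ccccc2)C2(CCN(C(=O)c3ccc(C4CCCCC4)cc3)CC2)C1=O` 4600 nM
compound 3 `CS(=O)(=O)NCCNC(=O)CN1CN(c2ccccc2)C2(CCN(C(=O)c3ccc(C4CCCCC4)cc3)CC2)C1=O` 2100 nM

In an assay on HEK293 cells for displacement of a labelled ligand from NPC1-like intracellular cholesterol transporter 1 (Homo sapiens) (a lower number here means a stronger inhibitor, a higher number a weaker inhibitor), compound 1 gives the lowest of the three numbers; compound 3 lies nearer to it and compound 2 furthest. Compound 4 `CC(C)(C)c1ccc(C(=O)N2CCC3(CC2)C(=O)N(CC(=O)N2CCCC(O)C2)CN3c2ccccc2)cc1` differs from compound 1 in one place: 3-hydroxypiperidin-1-yl in place of (2-hydroxyethyl)amino on a carbonyl carbon. Going by the values given here, no measured step changes this part of the shared core in the same way. Among the compounds with values here, the only step available, a 2.2-fold lower number from compound 2 to compound 3 (0.34 log units; beyond the scatter), alters the terminus of the same side chain and was modest. A modest shift, or none beyond the scatter, is therefore expected for compound 4 in this assay, a 1.3-fold higher number from compound 1 to compound 4 (0.11 log units; within the scatter). Compound 4 is estimated at 1300 nM, with a range from 500 nM to 3500 nM.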

Compound 4, half-maximal inhibitory concentration: 12200 nM
For compound 4 the middle estimate is 9.4-fold (0.97 log units) below the measured one; the measured number lies above the stated range.
By their numbers in this assay, from the lowest: compound 1; then compound 3; then compound 2; then compound 4.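

In this assay, going by these compounds alone, 3-hydroxypiperidin-1-yl in place of (2-hydroxyethyl)amino on the carbonyl carbon gives a 12-fold higher number from compound 1 to compound 4 (1.09 log units; beyond the scatter), a large step, whereas the only earlier step on this side chain, a 2.2-fold lower number from compound 2 to compound 3 (0.34 log units; beyond the scatter), was modest. This terminus is therefore not indifferent to change: closing a six-membered ring and losing the amide hydrogen together carry a clear penalty. No evidence on the cause of this step is available. The compounds shown leave open whether the ring or the lost amide hydrogen matters more. A methyl(2-hydroxyethyl)amino group on the same carbonyl carbon would separate the two.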